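Sulfonyl for carbonyl on the aromatic oxygen

This account rests on a few compounds, and the source may have more. Where it says the series, first, only, none or still open, it means among the compounds named here.

compound 1 `COc1ccc(/C=C/C(=O)c2ccc(OC)c3c2OC(C)(C)C=C3)cc1OCC=C(C)C`: > 10000 nM (a limit)
compound 2 `COc1ccc(/C=C/C(=O)c2ccc(OC)c3c2OC(C)(C)C=C3)cc1OC(=O)c1ccc(Br)cc1`: 1110 nM
compound 3 `COc1ccc(/C=C/C(=O)c2ccc(OC)c3c2OC(C)(C)C=C3)cc1OS(=O)(=O)c1ccc(C)cc1`: not yet measured

For the measured compounds named here, in a functional assay on K562 cells (Homo sapiens) for cytotoxicity, read by MTT assay (on this read-out lower numbers stand for stronger inhibition and higher numbers for weaker inhibition), compound 2 gives 1110 nM, the only actual number so far. Compound 1 sits at > 10000 nM, which is a limit of the assay.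

The next change is (4-methylphenyl)sulfonyl in place of (4-bromophenyl)carbonyl on an oxygen on an aromatic ring. Going by the values given here, one measured step bears on this oxygen: an at least 9.0-fold lower number from compound 1 to compound 2 (0.95 log units; beyond the scatter). That step removed a 3-methylbut-2-en-1-yl group, whereas compound 3 keeps an aromatic ring in the group, as compound 2 does with its 1110 nM. A much smaller change is therefore expected here, a 1.4-fold higher number from compound 2 to compound 3 (0.13 log units; within the scatter), with no clear direction. For compound 3 the expected value is 1500 nM, with an estimated range of 500 nM to 6000 nM.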

Compound 3, half-maximal inhibitory concentration: 7850 nM
Compound 3: middle estimate off by 5.2-fold (0.72 log units), on the low side, and the stated range ends below it.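

In this assay, an aromatic ring in the group on this oxygen does not by itself hold the level of compound 2, as the change to (4-methylphenyl)sulfonyl shows a 7.1-fold higher number from compound 2 to compound 3 (0.85 log units; beyond the scatter). Against the 3-methylbut-2-en-1-yl group, the comparison gives only a floor, an at least 1.2-fold lower number from compound 1 to compound 3 (0.10 log units; that floor lies within the scatter), so it establishes no order. The value of compound 1 is a limit, not a number: the limit of > 10000 nM in this assay, at which 1 of the 3 values shown sits.

The step changes both the sulfonyl-for-carbonyl link and the methyl-for-bromine ring substituent, so the compounds shown leave open which of the two accounts for it. A (4-bromophenyl)sulfonyl group on the same oxygen would separate them.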